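The source may report more compounds than this note shows. Statements on the series, on what has been measured and on what is new or still open speak of the compounds shown alone.

Measured compounds in a functional assay on OVCAR-5 cells (Homo sapiens) for inhibition, read by sulforhodamine B assay, with a stated time of 48 h; a lower number here means a stronger inhibitor of growth, a higher number a weaker inhibitor of growth:
compound 1 `COc1cc(-c2nn(-c3cccc(NC(=O)c4ccc(Cl)c(C(F)(F)F)c4)c3)cc2-c2ccncc2)ccc1Cl`
compound 2 `O=C(Nc1cccc(-n2cc(-c3ccncc3)c(-c3ccc(Cl)c(O)c3)n2)c1)Nc1cc(C(F)(F)F)cc(C(F)(F)F)c1`
compound 3 `O=C(Nc1cccc(-n2cc(-c3ccncc3)c(-c3ccc(Cl)c(O)c3)n2)c1)Nc1ccc(Cl)c(C(F)(F)F)c1`

In this assay compound 1 gives only a limit, > 32500 nM. Compound 2 gives 875 nM and compound 3 gives 1570 nM; neither differs from compound 1 in one place, so no single step can be read from them. Compound 1 thus sits at the limit of > 32500 nM in this assay, at which 1 of the 3 values shown sits, with no number of its own.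

Compound 4 `COc1cc(-c2nn(-c3cccc(NC(=O)Nc4ccc(Cl)c(Cl)c4)c3)cc2-c2ccncc2)ccc1Cl` is not yet measured. It differs from compound 1 by (3,4-dichlorophenyl)amino in place of 4-chloro-3-(trifluoromethyl)phenyl on a carbonyl carbon, the (3,4-dichlorophenyl)amino entering on the carbonyl carbon whose other neighbour is the amide-type nitrogen.

Compound 1 shows only a limit, so the size of the step is uncertain; a move towards stronger inhibition in this assay is expected, as in an at least 6.5-fold lower number from compound 1 to compound 4 (0.81 log units; beyond the scatter). Compound 4 is estimated at 5000 nM, between 1200 nM and 25000 nM.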

Compound 4, concentration for 50% growth inhibition: 2130 nM
The estimate for compound 4 lay 2.3-fold (0.37 log units) above the measured number; measured number inside the range.
By their numbers in this assay, from the lowest: compounds 2, 3 and 4 (each within the scatter of the next, the first and the last beyond it). At a limit, above all of these: compound 1.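

In this assay, among these compounds, (3,4-dichlorophenyl)amino in place of 4-chloro-3-(trifluoromethyl)phenyl on the carbonyl carbon gives an at least 15-fold lower number from compound 1 to compound 4 (1.18 log units; beyond the scatter), the only single change that can be read so far. Compound 1 gives only a limit, > 32500 nM. The step therefore stands as a bound and not as a size, because compound 1 has no number of its own: the limit of > 32500 nM in this assay, at which 1 of the 4 values shown sits.

On these data alone, the nitrogen and the ring substituents change together, and the share of each in the step remains open. Also open, as far as these compounds go, is whether a morpholine or a longer alkyl chain on that carbonyl carbon would retain growth inhibition.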